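Coumarin ester series: aryl ether variation

A few compounds are considered here, and "the series" means these few. Any claim that something is new, unique, unknown or untested is made for them only; others in the source may bear on it.

Measured so far:
compound 1 `C#CCCCCOc1ccc2oc(=O)c(C(=O)OC)cc2c1` — 123 nM
compound 2 `COC(=O)c1cc2cc(OCc3cccc(Cl)c3)ccc2oc1=O` — 31.5 nM

In an assay on cells for inhibition of Amine oxidase [flavin-containing] B (Homo sapiens), read by Amplex Red, with stated times of 30 min and 45 min (a higher number here means a weaker inhibitor, a lower number a stronger inhibitor), compound 2 gives the lowest of the two numbers; the nearest is compound 1, and the step of a 3.9-fold lower number from compound 1 to compound 2 (0.59 log units; beyond the scatter) lies beyond the scatter. Compound 3 `COC(=O)c1cc2cc(OCCc3ccc(Cl)cc3)ccc2oc1=O` differs from compound 2 by 4-chlorobenzyl in place of 3-chlorophenyl on a saturated chain carbon bound to an oxygen on an aromatic ring. For the measured compounds named here, no measured step bears directly on this change: the one step recorded swaps an alkyne chain for an aryl group, not one aryl group for another. The expectation for compound 3 is therefore a step of a 1.3-fold higher number from compound 2 to compound 3 (0.10 log units; within the scatter) that stays within the scatter. Compound 3 is estimated at 40 nM, with a range from 12 nM to 130 nM.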

Compound 3, half-maximal inhibitory concentration: 120 nM
The estimate for compound 3 lay 3.0-fold (0.48 log units) below the measured number, within the range that was stated.
By their numbers in this assay, from the lowest: compound 2; then compounds 3 and 1 (each within the scatter of the next).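

The aryl group on this saturated chain carbon does not settle the number by itself: 4-chlorobenzyl in place of 3-chlorophenyl gives a 3.8-fold higher number from compound 2 to compound 3 (0.58 log units; beyond the scatter). The alkyne chain and the 4-chlorobenzyl group also sit level, with a 1.0-fold lower number from compound 1 to compound 3 (0.01 log units; within the scatter), so the gain at compound 2 belongs to 3-chlorophenyl rather than to any chlorinated aryl group. Nothing at hand accounts for either step.

The step to compound 3 moves the chlorine and lengthens the link together, leaving the two changes unseparated. Unsubstituted phenyl, 3-chlorobenzyl and a carboxylic acid in place of the methyl ester remain open.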